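This account rests on a few compounds, and the source may have more. Where it says the series, first, only, none or still open, it means among the compounds named here.

Compound 3 `O=C1c2c[n+]([O-])c3ccccc3c2C(=O)c2[nH]c3ccccc3c21` gives 320 nM in a functional assay on A549 cells (Homo sapiens) for cytotoxicity, read by MTT assay, with a stated time of 72 h (on this read-out higher numbers stand for weaker inhibition and lower numbers for stronger inhibition), the lowest of the three numbers recorded, though compound 1 `CN1CCN(CCCCCCn2c3c(c4ccccc42)C(=O)c2c[n+]([O-])c4ccccc4c2C3=O)CC1` sits within the scatter of it at 330 nM; compound 2 `CN1CCN(CCCCCn2c3c(c4ccccc42)C(=O)c2c[n+]([O-])c4ccccc4c2C3=O)CC1` gives 870 nM. The step to compound 4 `O=C1c2c[n+]([O-])c3ccccc3c2C(=O)c2c1c1ccccc1n2CCCCN1CCCCC1` is 4-(piperidin-1-yl)butyl in place of hydrogen on an aromatic nitrogen. Within the data shown here, two measured steps bear on it: a 2.7-fold lower number from compound 2 to compound 3 (0.43 log units; beyond the scatter), where removing a chain of this kind lowered the number, and a 2.6-fold higher number from compound 1 to compound 2 (0.42 log units; beyond the scatter), where a shorter chain raised it. Compound 4 carries a chain shorter still, so a modest rise beyond the scatter is expected, a 2.8-fold higher number from compound 3 to compound 4 (0.45 log units; beyond the scatter). Compound 4 is therefore estimated at 900 nM in this assay, with a range from 300 nM to 2500 nM.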

Compound 4, half-maximal inhibitory concentration: 150 nM
The estimate for compound 4 lay 6.0-fold (0.78 log units) above the measured number; the measured number lies below the stated range.
By their numbers in this assay, from the lowest: compound 4; then compounds 3 and 1 (each within the scatter of the next); then compound 2.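

In this assay, a chain on this aromatic nitrogen need not raise the number: 4-(piperidin-1-yl)butyl lowers it (a 2.1-fold lower number from compound 3 to compound 4 (0.33 log units; beyond the scatter)). The same chain also gives a lower number than either 4-methylpiperazine chain (a 5.8-fold lower number from compound 2 to compound 4 (0.76 log units; beyond the scatter); a 2.2-fold lower number from compound 1 to compound 4 (0.34 log units; beyond the scatter)), so the earlier rise on shortening the chain does not extend to compound 4. Nothing available accounts for these steps.

Compound 4 differs from compound 1 and compound 2 in both its ring and its chain, so the two changes cannot be separated. On these data alone, whether a 4-(4-methylpiperazin-1-yl)butyl or a 6-(piperidin-1-yl)hexyl chain would behave like compound 4 remains open.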